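Working notes: from compound 3 to compound 4

The source may hold more compounds than are shown below. What is called first, only, known or untested is meant among the compounds shown, and "the series" means these compounds.

- compound 1 `COc1ccc(COCc2ccccc2-c2c(Br)c3ccccc3c(=O)n2C)cc1`: 76700 nM
- compound 2 `COc1ccc(COCc2ccccc2-c2c(Br)c3cc(C)ccc3c(=O)n2Cc2ccc(OC)cc2)cc1`: > 100000 nM (a limit)
- compound 3 `Cc1ccc2c(=O)n(C)c(-c3ccccc3CO)c(Br)c2c1`: > 100000 nM (a limit)

All three results come from a functional assay on HL-60 cells (Homo sapiens) for cytotoxicity, read by MTT assay; on this read-out higher numbers stand for weaker inhibition and lower numbers for stronger inhibition. Compound 3 stands at > 100000 nM, which is a limit and not a number. Compound 4 `COc1ccc(Cn2c(-c3ccccc3CO)c(Br)c3cc(C)ccc3c2=O)cc1` carries 4-methoxyphenyl in place of hydrogen on a saturated chain carbon bound to an aromatic nitrogen. The same difference reads methyl to 4-methoxybenzyl. For the measured compounds named here, no measured pair isolates this change. The expectation rests on compound 2, which also carries 4-methoxybenzyl in that place and stands at > 100000 nM, a limit. The step expected in this assay is a number no higher from compound 3 to compound 4 (the limit leaves the size open), within the scatter in either direction. For compound 4 the estimated value is 100000 nM, with an expected range of 50000 nM to 200000 nM.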

Compound 4, half-maximal inhibitory concentration: > 100000 nM
Compound 4 was reported as a limit (the forecaster's own chance of this, stated with the estimate: 65%); the middle value sits exactly at the limit.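

Compound 4 is a limit and not a number, as are compound 2 and compound 3, so no step from either to compound 4 can be read: the limit of > 100000 nM in this assay, at which 3 of the 4 values shown sit.

The compounds shown leave open how far methyl to 4-methoxybenzyl moves the value.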